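A few compounds are considered here, and "the series" means these few. Any claim that something is new, unique, unknown or untested is made for them only; others in the source may bear on it.

Three compounds that share the same core, plus one built on a different core, have been measured in a functional assay on CHO cells for antagonist activity at Orexin/Hypocretin receptor type 1 (Homo sapiens), read by FLIPR and calcium flux; a lower number here means a less potent compound, a higher number a more potent compound, by a factor of ten per unit of this negative logarithm. Compound 1 `Cc1cc(C(F)(F)F)cc(NC[C@@H]2CC3(CC3)CN2C(=O)c2nc(C)sc2-c2ccccc2)n1` gives 7.8. Compound 2 `Cc1cccc(NC[C@@H]2CC3(CC3)CN2C(=O)c2nc(C)sc2-c2ccccc2)n1` gives 7.3, and compound 3 `O=C(c1cc(Cl)ccc1-c1ncccn1)N1CC2(CC2)C[C@H]1CNc1cc(C(F)(F)F)ccn1` gives 8.1. Compound 2 stands lowest of the three: compound 1 sits above it beyond the scatter, and compound 3 sits further above it. Among the measured compounds shown here, the single step between neighbours differing in one place runs a number 0.50 log units lower from compound 1 to compound 2 (beyond the scatter), so removing a trifluoromethyl group from the aromatic ring went with a modest loss.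

Compound 4 `Cc1nc(C(=O)N2CC3(CC3)C[C@H]2CNc2cc(C(F)(F)F)ccn2)c(-c2ccccc2)s1` has not yet been measured. It differs from compound 2 by 4-(trifluoromethyl)pyridin-2-yl in place of 6-methylpyridin-2-yl on an amine nitrogen, a change that brings a trifluoromethyl group back onto the aromatic ring while the methyl group departs. The step from compound 1 to compound 2 bears on this directly, and compound 3, which carries the same 4-(trifluoromethyl)pyridin-2-yl group on another core, gives the highest number seen. Compound 4 is therefore expected to gain, with an estimated step of a number 0.60 log units higher from compound 2 to compound 4 (beyond the scatter). The estimate for compound 4 in this assay is 7.9, within a range from 7.4 to 8.4.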

Compound 4, negative logarithm of the antagonist equilibrium constant: 8.2
Beside the measured number, compound 4's estimate is 0.30 log units below it, within the range that was stated.
By their numbers in this assay, from the lowest: compound 2; then compounds 1, 3 and 4 (each within the scatter of the next, the first and the last beyond it).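

The methyl group of compound 1 turns out not to be needed for potency in this assay: with the trifluoromethyl group kept on the ring, putting hydrogen in place of that methyl gives a number 0.40 log units higher from compound 1 to compound 4 (beyond the scatter). Exchanging 6-methylpyridin-2-yl for 4-(trifluoromethyl)pyridin-2-yl on the amine nitrogen therefore combines the loss of a group that was not helping with the gain of one that was, and together they give a number 0.90 log units higher from compound 2 to compound 4 (beyond the scatter). Nothing measured here explains why either group has this effect on the number.

The compounds shown leave open how a plain pyridin-2-yl, carrying neither group, would compare, so the separate contribution of the methyl group without trifluoromethyl on the ring remains unknown. On these data alone, it is also open whether a chloro, methoxy or nitrile group could take the place of the trifluoromethyl group on this ring and hold the number.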